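Solubility outlook for the cyclopentyl analogue

The compounds below may be only part of what the source reports. "The series", "measured", "known", "first", "only" and "open" are said of these compounds alone.

Values measured so far in a physicochemical assay for solubility, read by HPLC, using the shake flask method, in phosphate buffer, with a stated time of 20 h, at pH 6.5; a higher number here means a more soluble compound, a lower number a less soluble compound

compound 1 `CN1CCN(C2CCN(c3nccc4[nH]c(-c5cccc(OC(F)(F)F)c5)nc34)CC2)CC1` gives 190000 nM
compound 2 `CN1CCN(C2CCN(c3nccc4[nH]c(-c5cc(F)cc(F)c5)nc34)CC2)CC1` gives 200000 nM
compound 3 `CN1CCN(C2CCN(c3nccc4[nH]c(-c5cccc(S(C)(=O)=O)c5)nc34)CC2)CC1` gives 190000 nM

On these numbers, compound 3 sits level with compound 1 and within the scatter of compound 2. The next structure is compound 4 `CN1CCN(C2CCN(c3nccc4[nH]c(C5CCCC5)nc34)CC2)CC1` with cyclopentyl in place of 3-(methylsulfonyl)phenyl on an aromatic carbon, counted as follows: cyclopentyl in place of 3-(methylsulfonyl)phenyl on an aromatic carbon and nothing else differs.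

All three measured steps bear on this change, since each exchanges the group at the same place: a 1.1-fold higher number from compound 1 to compound 2 (0.02 log units; within the scatter) and no change at the digits printed from compound 1 to compound 3 (within the scatter) and a 1.1-fold lower number from compound 2 to compound 3 (0.02 log units; within the scatter) all lie within the scatter. None of them replaces the phenyl ring with a non-aromatic ring, so compound 4 goes beyond what has been measured. In this assay no step beyond the scatter is expected and no direction can be given, so the estimated step is no change at the digits printed from compound 3 to compound 4 (within the scatter) with wide uncertainty. For compound 4 the estimate is 190000 nM with an expected range from 110000 nM to 260000 nM in this measurement.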

Compound 4, solubility: 170000 nM
Estimate against measurement, compound 4: 1.1-fold (0.05 log units) above; measured number inside the range.
By their numbers in this assay, from the lowest: compounds 4, 1, 3 and 2 (each within the scatter of the next).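

In this assay, the position on an aromatic carbon between two ring nitrogen atoms now tolerates the loss of the aromatic ring within the scatter: a 1.1-fold lower number from compound 3 to compound 4 (0.05 log units; within the scatter) and a 1.2-fold lower number from compound 2 to compound 4 (0.07 log units; within the scatter) and a 1.1-fold lower number from compound 1 to compound 4 (0.05 log units; within the scatter) all say the same. The earlier compounds shown here exchanged only one substituted phenyl for another, whereas cyclopentyl brings a non-aromatic ring of carbon only, with 5 heavy atoms, fewer than 3-(methylsulfonyl)phenyl has, and no hydrogen-bond acceptors against its 2. No supporting measurement is available to explain this flat result.

Still open, from the compounds shown here alone, is whether an amine, a carboxylic acid or a longer alkyl chain at this position would also stay within the scatter. The rest of the shared core is identical across all four compounds, so its part in the measured level cannot be read from them.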